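Second chloro on the chlorophenyl group of compound 3

The compounds below may be only part of what the source reports. "The series", "measured", "known", "first", "only" and "open" are said of these compounds alone.

Compound 3 `COc1ccc(/C=C2\CCC/C(=C\c3ccc(Cl)cc3)C2=O)cc1OC` gives 6300 nM in a functional assay on MCF7 cells (Homo sapiens) for cytotoxicity, read by MTT assay, with a stated time of 72 h (a higher number here means a weaker inhibitor, a lower number a stronger inhibitor), the lowest of the three numbers shown, though within the scatter of compound 1 `COc1cccc(/C=C2\CCC/C(=C\c3ccccc3Cl)C2=O)c1OC` at 11300 nM and of compound 2 `COc1cccc(/C=C2\CCC/C(=C\c3cccc(Br)c3)C2=O)c1OC` at 11700 nM. Compound 4 `COc1ccc(/C=C2\CCC/C(=C\c3ccc(Cl)c(Cl)c3)C2=O)cc1OC` differs from compound 3 by chloro in place of hydrogen on an aromatic carbon. Among the measured compounds shown here, the one measured step, a 1.0-fold higher number from compound 1 to compound 2 (0.02 log units; within the scatter), exchanges one halogenated phenyl for another and does not add a chloro to a ring already bearing one; no measured pair shows that change, so it bears only loosely here. As the halogen steps seen stay within the scatter, for compound 4 the expected step is a 1.1-fold lower number from compound 3 to compound 4 (0.06 log units; within the scatter), within the scatter. The estimate for compound 4 is 5500 nM, range 2500 nM to 12000 nM.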

Compound 4, half-maximal inhibitory concentration: 4400 nM
Beside the measured number, compound 4's estimate is 1.3-fold (0.10 log units) above it, and the stated range covers the measured number.
By their numbers in this assay, from the lowest: compounds 4, 3, 1 and 2 (each within the scatter of the next, the first and the last beyond it).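

In this assay, among the compounds shown here, the change from 4-chlorophenyl to 3,4-dichlorophenyl gives a 1.4-fold lower number from compound 3 to compound 4 (0.16 log units; within the scatter) and is the first measured step that adds a chloro to a ring already bearing one. A second chloro on this aromatic carbon, ortho to the first, is tolerated, with no change that can be told from the scatter. No measured evidence bears on the reason for this result. Still open, on these data alone, is whether an amine or a carboxylic acid on this same aromatic carbon would shift the number beyond the scatter.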